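A few compounds are considered here, and "the series" means these few. Any claim that something is new, unique, unknown or untested is made for them only; others in the source may bear on it.

In a functional assay on HO8910 cells (Homo sapiens) for inhibition, read by MTT assay, with a stated time of 24 h, tested at 100 ug/mL (on this read-out higher numbers stand for more inhibition of growth at the one concentration tested and lower numbers for less inhibition of growth), compound 1 `O=C(CCCCC(S)CCS)NO` gives 49.3%. Compound 2 `O=C(CCCCC(S)CCS)Nc1ccccc1` gives 13.7%, the lower of the two numbers available. Phenyl in place of hydroxy on an amide-type nitrogen accounts for a number 35.6 percentage points lower from compound 1 to compound 2 (beyond the scatter), a large step beyond the scatter. Compound 3 `O=C(CCCCC(S)CCS)Nc1ccccc1Cl`, which also carries a chloro group on its aromatic ring, is reported as "not active" (no number reported), so no number exists for it.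

The open question is compound 4 `O=C(CCCCC(S)CCS)Nc1cccc(Cl)c1`. It differs from compound 2 as follows: chloro in place of hydrogen on an aromatic carbon. In words, this is chloro in place of hydrogen on an aromatic carbon, meta to a large group. Going by the values given here, the one measured step, a number 35.6 percentage points lower from compound 1 to compound 2 (beyond the scatter), involves a different change at a different place, so it does not set the size of this one. Among the compounds with values here, the closest evidence is compound 3 at "not active" (no number reported), which offers no measurable step but gives no sign of a gain from chloro. In this assay, no step beyond the scatter is therefore expected, with any drift more likely downward. The estimate amounts to a number 3.7 percentage points lower from compound 2 to compound 4 (within the scatter), an expected step within the scatter. Compound 4 is expected to give about 10%, with an estimated range from 0% to 24%.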

Compound 4, percent growth inhibition at one concentration: "not active" (no number reported)
No number was reported for compound 4, so the estimate cannot be set against anything.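

In this assay, going by these compounds alone, compound 4 gives "not active" (no number reported) and so no step from compound 2 to compound 4 can be read, nor any comparison with compound 3. Nothing measured here bears on this result. The compounds shown leave open how much growth inhibition, if any, compound 3 and compound 4 retain relative to compound 2.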